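The source may report more compounds than this note shows. Statements on the series, on what has been measured and on what is new or still open speak of the compounds shown alone.

Measured compounds in a functional assay on NCI-H460 cells (Homo sapiens) for cytotoxicity, read by MTT assay, with a stated time of 72 h; on this read-out higher numbers stand for weaker inhibition and lower numbers for stronger inhibition:
- compound 1 `COc1cc2c(Oc3ccc(NC(=O)c4cc(-c5ccccc5)ccn4)cc3F)ccnc2cc1OCCCN1CCN(C)CC1`: 91 nM
- compound 2 `COc1cc2c(Oc3ccc(NC(=O)c4cc(-c5ccc(C(F)(F)F)cc5)ccn4)cc3F)ccnc2cc1OCCCN1CCCCC1`: 360 nM
- compound 3 `COc1cc2c(Oc3ccc(NC(=O)c4cc(-c5ccccc5F)ccn4)cc3F)ccnc2cc1OCCCN1CCN(C)CC1`: 140 nM

Compound 3 stands second highest of the three numbers in this assay. Its nearest neighbour is compound 1, and the step of a 1.5-fold higher number from compound 1 to compound 3 (0.19 log units; within the scatter) lies within the scatter, so the two cannot be ordered. Compound 2 is furthest away, its number standing beyond the scatter above that of compound 3.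

Compound 4 `COc1cc2c(Oc3ccc(NC(=O)c4cc(-c5ccc(C(F)(F)F)cc5)ccn4)cc3F)ccnc2cc1OCCCN1CCN(C)CC1` is not yet measured. It differs from compound 3 in one place: 4-(trifluoromethyl)phenyl in place of 2-fluorophenyl on an aromatic carbon. Going by the values given here, no measured step covers exactly this change. Among the compounds with values here, the only measured step on the same aromatic carbon, a 1.5-fold higher number from compound 1 to compound 3 (0.19 log units; within the scatter), is small and within the scatter. Compound 2 carries the same 4-(trifluoromethyl)phenyl group as compound 4 but a different end on the chain, and in this assay compound 2 gives 360 nM, the highest number of the three; this is the closest indication available, though the chain end differs.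

On this basis a modest rise in the number is expected, near the edge of the scatter. Compound 4 is estimated at 250 nM, with a range of 110 nM to 600 nM, which corresponds to an expected step of a 1.8-fold higher number from compound 3 to compound 4 (0.25 log units; within the scatter).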

Compound 4, half-maximal inhibitory concentration: 160 nM
Beside the measured number, compound 4's estimate is 1.6-fold (0.19 log units) above it; measured number inside the range.
By their numbers in this assay, from the lowest: compounds 1, 3 and 4 (each within the scatter of the next); then compound 2.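

In this assay the step of a 1.1-fold higher number from compound 3 to compound 4 (0.06 log units; within the scatter) and the step of a 1.8-fold higher number from compound 1 to compound 4 (0.25 log units; within the scatter) both lie within the scatter, so with 4-methylpiperazin-1-yl at the chain end, neither 4-(trifluoromethyl)phenyl nor 2-fluorophenyl on the aromatic carbon opposite the ring nitrogen can be told apart from the unsubstituted phenyl. Going by these compounds alone, the high number of compound 2 therefore does not follow from 4-(trifluoromethyl)phenyl alone: with that group held fixed, 4-methylpiperazin-1-yl in place of piperidin-1-yl gives the step of a 2.3-fold lower number from compound 2 to compound 4 (0.35 log units; beyond the scatter) and this modest change is the first step beyond the scatter, and it lies at the chain end rather than on the aromatic carbon. No supporting measurement accompanies these numbers that would bear on the result.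

The compounds shown leave open whether the chain-end step recurs with phenyl or 2-fluorophenyl on the aromatic carbon, and whether a morpholine at the chain end would fall with 4-methylpiperazin-1-yl or with piperidin-1-yl. They also leave open whether an amine or a carboxylic acid on the phenyl ring would move the number beyond the scatter, as the groups compared here do not.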